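Hydroxy for Bromo on the Arylidene Ring of Compound 1

This account rests on a few compounds, and the source may have more. Where it says the series, first, only, none or still open, it means among the compounds named here.

Compound 1 `O=C(/C(=C\c1ccc(Br)cc1)SCc1ccc(Cl)cc1)c1ccc(Cl)cc1` was tested in a functional assay on DU-145 cells (Homo sapiens) for inhibition, read by trypan blue exclusion, with a stated time of 96 h (on this read-out higher numbers stand for weaker inhibition of growth and lower numbers for stronger inhibition of growth), and gave 1000 nM. Compound 2 `O=C(/C(=C\c1ccc(Br)cc1)SCc1ccc(Cl)cc1)c1ccc(Br)cc1` gave 1000 nM, and compound 3 `O=C(/C(=C\c1ccc(Br)cc1)SCc1ccc(F)cc1)c1ccc(Cl)cc1` gave 9000 nM. Compound 1 therefore stands level with compound 2, the two together at the lowest numbers of the three, and well apart from compound 3.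

The step of no change at the digits printed from compound 1 to compound 2 (within the scatter) shows that exchanging one halogen for another on the benzoyl ring leaves the number unchanged, whereas the step of a 9.0-fold higher number from compound 1 to compound 3 (0.95 log units; beyond the scatter) shows a modest rise when a smaller halogen replaces chloro on the benzylthio ring.

Compound 4 `O=C(/C(=C\c1ccc(O)cc1)SCc1ccc(Cl)cc1)c1ccc(Cl)cc1` differs from compound 1 by hydroxy in place of bromo on an aromatic carbon. For the measured compounds named here, neither measured step touches this ring, and neither replaces a halogen with a hydroxy group, so the two steps bear only loosely on it; the change is larger than either halogen swap, and the one step that was beyond the scatter went upward. Compound 4 is therefore expected to show a moderately higher number than compound 1, a step of about a 3.0-fold higher number from compound 1 to compound 4 (0.48 log units; beyond the scatter). The estimate for compound 4 is 3000 nM, with a range from 700 nM to 15000 nM.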

Compound 4, concentration for 50% growth inhibition: 10000 nM
Estimate against measurement, compound 4: 3.3-fold (0.52 log units) below, and the stated range covers the measured number.
By their numbers in this assay, from the lowest: compounds 1 and 2 (each within the scatter of the next); then compounds 3 and 4 (each within the scatter of the next).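

In this assay, hydroxy in place of bromo gives a 10-fold higher number from compound 1 to compound 4 (1.00 log units; beyond the scatter) and so weaker inhibition of growth. This is the first step shown at this position, on an aromatic carbon para to a large group, and it shows that the number responds to what stands there. For the compounds shown here, the only earlier step beyond the scatter, a 9.0-fold higher number from compound 1 to compound 3 (0.95 log units; beyond the scatter), lay at another place in the molecule, and neither earlier step put a hydrogen-bond donor or acceptor in place of a halogen. No measured evidence shown here accounts for the rise.

The compounds shown leave open whether the rise belongs to hydroxy in particular or simply to the departure of bromo. A methoxy group or an amine on the same aromatic carbon would help tell these two readings apart.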